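A few compounds are considered here, and "the series" means these few. Any claim that something is new, unique, unknown or untested is made for them only; others in the source may bear on it.

Compound 1 `O=C1/C(=C/c2ccc(Br)cc2)CCc2ccccc21`: 20400 nM
Compound 2 `COc1ccc(/C=C2\CCCc3ccccc3C2=O)cc1`: 1600 nM
Compound 3 `O=C1CCCCC/C1=C\c1cccc(F)c1`: > 50000 nM (a limit)

In a functional assay on P388 cells (Mus musculus) for inhibition (a higher number here means a weaker inhibitor, a lower number a stronger inhibitor), compound 3 gives only a limit, > 50000 nM, and not a number. Compound 4 `O=C1CCCCC/C1=C\c1cccc(Br)c1` is compound 3 with one change, bromo in place of fluoro on an aromatic carbon. For the measured compounds named here, no measured pair shows this swap alone, so the expectation rests on thin evidence. Compound 1 also carries a bromo group, on a different core, and gives 20400 nM. That value points to a small expected move toward stronger inhibition, and compound 4 may again give only a limit. The expected change is an at least 1.4-fold lower number from compound 3 to compound 4 (0.15 log units; that floor lies within the scatter). For compound 4 the estimated value is 35000 nM, with an expected range of 12000 nM to 60000 nM.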

Compound 4, half-maximal inhibitory concentration: 24100 nM
Compound 4: middle estimate off by 1.5-fold (0.16 log units), on the high side; the measured number falls inside the stated range.
By their numbers in this assay, from the lowest: compound 2; then compounds 1 and 4 (each within the scatter of the next). At a limit, above all of these: compound 3.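

In this assay, putting bromo in place of fluoro on this aromatic carbon gives a measurable number rather than a limit, with an at least 2.0-fold lower number from compound 3 to compound 4 (0.31 log units; beyond the scatter). This is the first single change among these compounds that can be read as a step, and it lies beyond the scatter. Its full size stays unknown because compound 3 gives only a limit of the assay: the limit of > 50000 nM in this assay, at which 1 of the 4 values shown sits.

Still open, on these data alone, is how an amine or a carboxylic acid would behave at this place. Also open, as far as these compounds go, is whether this swap has the same effect on another core.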